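The compounds below may be only part of what the source reports. "The series", "measured", "known", "first", "only" and "open" are said of these compounds alone.

Measured compounds:
compound 1, `CC(Nc1ccccc1Oc1cccc(F)c1)=C1C(=O)CC(c2ccccc2)CC1=O`, 330 nM
compound 2, `CC(Nc1ccccc1Oc1ccc(Cl)cc1)=C1C(=O)CC(c2ccccc2)CC1=O`, 250 nM
compound 3, `COc1ccc(Oc2ccccc2NC(C)=C2C(=O)CC(c3ccccc3)CC2=O)cc1OC`, 65 nM

These three compounds were tested in a functional assay on L1210 cells (Mus musculus) for antiproliferative activity, read by cell counting, with a stated time of 96 h; a higher number here means a weaker inhibitor, a lower number a stronger inhibitor. Compound 3 stands at the lowest number of the three: the step of a 5.1-fold lower number from compound 1 to compound 3 (0.71 log units; beyond the scatter) and the step of a 3.8-fold lower number from compound 2 to compound 3 (0.59 log units; beyond the scatter) both lie beyond the scatter, while the step of a 1.3-fold lower number from compound 1 to compound 2 (0.12 log units; within the scatter) does not. So the 3,4-dimethoxyphenyl on the ether oxygen goes with a clearly stronger inhibitor than either halogen-bearing phenyl.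

Compound 4, `COc1cc(Oc2ccccc2NC(C)=C2C(=O)CC(c3ccccc3)CC2=O)ccc1N`, has not yet been measured. It differs from compound 3 in one place: amino in place of methoxy on an aromatic carbon. The change sits on an aromatic carbon of a six-membered aromatic ring of carbon only, ortho to a methoxy group and para to a large group.

Within the data shown here, none of the measured steps swaps a methoxy for an amino; they only swap the whole aryl group on the oxygen. The two steps ending in compound 3 show that this ring tolerates two methoxy groups well, but they say nothing about an amino in that spot. The expected outcome is therefore a step of a 1.5-fold higher number from compound 3 to compound 4 (0.19 log units; within the scatter) in this assay, small and possibly within the scatter. Compound 4 is estimated at 100 nM, with a range from 40 nM to 260 nM.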

Compound 4, half-maximal inhibitory concentration: 26 nM
Compound 4: middle estimate off by 3.8-fold (0.59 log units), on the high side; measured number below the stated range.
By their numbers in this assay, from the lowest: compound 4; then compound 3; then compounds 2 and 1 (each within the scatter of the next).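

In this assay, changing one methoxy group to amino gives a 2.5-fold lower number from compound 3 to compound 4 (0.40 log units; beyond the scatter), so this position responds to a single small substitution and not only to a swap of the whole aryl group on the oxygen. The 4-amino-3-methoxyphenyl group also gives a 9.6-fold lower number from compound 2 to compound 4 (0.98 log units; beyond the scatter) and a 13-fold lower number from compound 1 to compound 4 (1.10 log units; beyond the scatter), which places compound 4 beyond the scatter from all three earlier compounds and lowest of the four. No supporting measurement is available to explain why the amino compound is the stronger inhibitor.

The compounds shown leave open whether a hydroxyl, a dimethylamino or an acetamide in place of the amino would give a similarly low number. They also leave open whether the amino would have the same effect without the methoxy group ortho to it.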